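The compounds below may be only part of what the source reports. "The series", "measured", "known", "first", "only" and "open" are said of these compounds alone.

Values in an ADME assay on KB cells (Homo sapiens) for cytotoxicity, read by MTT assay, with a stated time of 72 h; on this read-out higher numbers stand for lower toxicity in this test and lower numbers for higher toxicity in this test:
compound 1 `Clc1ccc(Nc2nc(-c3ccccn3)cs2)nc1`: 98600 nM
compound 2 `Clc1ccc(Nc2nc(-c3ccccn3)c(Cl)s2)nc1`: 326000 nM
compound 3 `Clc1ccc(Nc2nc(-c3cccnn3)cs2)nc1`: 10300 nM
compound 4 `Clc1ccc(Nc2nc(-c3cccnn3)c(Cl)s2)nc1`: not yet measured

Compound 3 holds the lowest number of the three at 10300 nM. Its nearest neighbour is compound 1, with a 9.6-fold lower number from compound 1 to compound 3 (0.98 log units; beyond the scatter), while compound 2 lies furthest off at 326000 nM.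

The change under consideration is chloro in place of hydrogen on an aromatic carbon, next to the ring sulfur (chloro in place of hydrogen on an aromatic carbon). The same exchange has been measured once, on the pyridin-2-yl member of the series, as a 3.3-fold higher number from compound 1 to compound 2 (0.52 log units; beyond the scatter). That step is modest but beyond the scatter. The other measured step, a 9.6-fold lower number from compound 1 to compound 3 (0.98 log units; beyond the scatter), does not involve chloro, but it shows that the starting point for this exchange differs from the one already measured. One pair is thin support, and its size may not carry over to the pyridazin-3-yl member. A modest move toward a higher number in this assay is therefore expected, of about the same size as the measured chloro step. The estimated step is a 3.1-fold higher number from compound 3 to compound 4 (0.49 log units; beyond the scatter). Compound 4 is estimated at 32000 nM, with an expected range of 11000 nM to 100000 nM.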

Compound 4, half-maximal cytotoxic concentration: 28100 nM
Estimate against measurement, compound 4: 1.1-fold (0.06 log units) above; the range from low to high includes it.
By their numbers in this assay, from the lowest: compound 3; then compound 4; then compound 1; then compound 2.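

In this assay, chloro in place of hydrogen on the aromatic carbon next to the ring sulfur now has a second reading, on the pyridazin-3-yl member, a 2.7-fold higher number from compound 3 to compound 4 (0.44 log units; beyond the scatter), so the shift toward a higher number no longer rests on a single pair and its size carries over between the two cores: the same change on two cores in this assay, a 3.3-fold higher number (0.52 log units; beyond the scatter) from compound 1 to compound 2 and a 2.7-fold higher number (0.44 log units; beyond the scatter) from compound 3 to compound 4, 1.2-fold (0.08 log units) apart, within the scatter of two such steps. Among these compounds, the exchange of pyridin-2-yl for pyridazin-3-yl, previously seen only with hydrogen on this carbon, also persists with chloro present, a 12-fold lower number from compound 2 to compound 4 (1.06 log units; beyond the scatter), and keeps its size: the same change on two cores in this assay, a 9.6-fold lower number (0.98 log units; beyond the scatter) from compound 1 to compound 3 and a 12-fold lower number (1.06 log units; beyond the scatter) from compound 2 to compound 4, 1.2-fold (0.08 log units) apart, within the scatter of two such steps. Across compound 1, compound 2, compound 3 and compound 4, the two changes therefore behave as independent steps, with no compound going against this.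

As far as these compounds go, whether a methyl, a methoxy, an amine or a carboxylic acid on this carbon would shift the number in the same direction as chloro remains open. The compounds shown do not give the cause of either step, and two cores cannot show whether the chloro step would hold on a further core.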